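One More Methoxy Group, Placed Two Different Ways

The source may hold more compounds than are shown below. What is called first, only, known or untested is meant among the compounds shown, and "the series" means these compounds.

Four compounds share a common core and differ only in how many methoxy groups sit on one aromatic ring and where they sit. Compound 1 `C=C(Br)C(=O)Nc1ccc(C(=O)/C=C/c2ccc(OC)cc2OC)cc1` and compound 2 `C=C(Br)C(=O)Nc1ccc(C(=O)/C=C/c2cc(OC)cc(OC)c2)cc1` are built from the same atoms joined differently; the difference between the two cores is not broken down here. In an ADME assay on CCRF-CEM cells (Homo sapiens) for antiproliferative activity, with a stated time of 48 h (on this read-out lower numbers stand for stronger inhibition and higher numbers for weaker inhibition), compound 1 gives 1100 nM, and compound 2 gives 2200 nM, two numbers that lie within the usual scatter of each other. Compound 3 `C=C(Br)C(=O)Nc1ccc(C(=O)/C=C/c2cc(OC)c(OC)c(OC)c2)cc1` arises from compound 2 by a single change, (methoxy in place of hydrogen on an aromatic carbon), and in this assay compound 3 gives 330 nM, a step of a 6.7-fold lower number from compound 2 to compound 3 (0.82 log units; beyond the scatter).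

Compound 4 `C=C(Br)C(=O)Nc1ccc(C(=O)/C=C/c2ccc(OC)c(OC)c2OC)cc1` has not yet been measured. It arises from compound 1 by the same kind of change, (methoxy in place of hydrogen on an aromatic carbon). In both cases a methoxy replaces hydrogen on an aromatic carbon ortho to two methoxy groups, but in compound 3 that carbon is para to a large group, whereas in compound 4 it is meta to a large group. Because a 6.7-fold lower number from compound 2 to compound 3 (0.82 log units; beyond the scatter) went beyond the scatter, and compound 1 starts at 1100 nM, compound 4 is expected to show a step of about a 2.8-fold lower number from compound 1 to compound 4 (0.44 log units; beyond the scatter). The place of the change differs in the two cases, and the expected step for compound 4 is set somewhat smaller than the measured one. The estimate for compound 4 is 400 nM, with a range from 120 nM to 1300 nM.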

Compound 4, half-maximal inhibitory concentration: 840 nM
Compound 4: the middle estimate sits 2.1-fold (0.32 log units) below what was measured, within the range that was stated.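

In this assay, placing a methoxy group on the ring of compound 1 gave a step of a 1.3-fold lower number from compound 1 to compound 4 (0.12 log units; within the scatter), so on this core the change produced no shift that can be told apart from the ordinary variation between repeated measurements. For the compounds shown here, the same kind of change therefore did not carry over from one core to the other with the same size: the same change on two cores in this assay, a 6.7-fold lower number (0.82 log units; beyond the scatter) from compound 2 to compound 3 and a 1.3-fold lower number (0.12 log units; within the scatter) from compound 1 to compound 4, 5.1-fold (0.71 log units) apart, beyond the scatter of two such steps This shows that a result for this change on one arrangement of methoxy groups cannot simply be transferred to another arrangement, but with only one pair on each core it does not show why the two steps differ, nor whether the starting arrangement or the place of the new methoxy group matters more.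

The compounds shown leave open whether a different group on the same ring carbon, such as a hydroxyl group, an ethoxy group or a fluorine atom, would follow the methoxy results on either core. They also leave open how the two steps would compare if the bromine on the shared core were replaced by chlorine.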